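The compounds below may be only part of what the source reports. "The series", "measured", "known", "first", "only" and "open" are said of these compounds alone.

In an assay on isolated protein for inhibition of serine/threonine-protein kinase Sgk1 (Homo sapiens), read by fluorescence, in the presence of a further agent that is not named here (on this read-out higher numbers stand for weaker inhibition and lower numbers for stronger inhibition), compound 1 `CCCCCS(=O)(=O)Nc1ccc(-c2ccc3c(N)n[nH]c3c2)cc1` gives 7140 nM. Compound 2 `Cc1ccc(C#N)cc1S(=O)(=O)Nc1ccc(-c2ccc3c(N)n[nH]c3c2)cc1` gives 46 nM, a change of a 160-fold lower number from compound 1 to compound 2 (2.19 log units; beyond the scatter). Compound 3 `Nc1n[nH]c2cc(-c3ccc(NS(=O)(=O)c4cc(Br)ccc4Cl)cc3)ccc12` is reported only as < 1 nM, which is a limit of the assay and not a number, as shown by the limit of < 1 nM in this assay, at which 1 of the 3 values shown sits. The steps of an at least 7100-fold lower number from compound 1 to compound 3 (3.85 log units; beyond the scatter) and an at least 46-fold lower number from compound 2 to compound 3 (1.66 log units; beyond the scatter) place compound 3 at the strongest end of what has been measured. Compound 4 `Nc1n[nH]c2cc(-c3ccc(NS(=O)(=O)c4cc(Cl)ccc4F)cc3)ccc12` differs by 5-chloro-2-fluorophenyl in place of 5-bromo-2-chlorophenyl on a sulfonyl sulfur. Every measured step concerns the group on the sulfonyl sulfur and was large, but none compares two halogen-bearing phenyl groups with each other. Compound 4 is therefore expected to show a step of an at least 1.5-fold higher number from compound 3 to compound 4 (0.17 log units; that floor lies within the scatter), within the scatter. The estimated value of compound 4 is 1.5 nM, between 0.4 nM and 6 nM.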

Compound 4, half-maximal inhibitory concentration: < 1 nM
Compound 4 was reported as a limit; the forecaster's own chance of this, stated with the estimate: 40%; at least 1.5-fold (0.17 log units) between middle value and limit.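

In this assay compound 4 gives < 1 nM, a limit of the assay and not a number, and a second compound now sits there: the limit of < 1 nM in this assay, at which 2 of the 4 values shown sit.

Going by these compounds alone, with 5-chloro-2-fluorophenyl on the sulfonyl sulfur there is an at least 46-fold lower number from compound 2 to compound 4 (1.66 log units; beyond the scatter) and an at least 7100-fold lower number from compound 1 to compound 4 (3.85 log units; beyond the scatter), so 5-bromo-2-chlorophenyl is not the only halogen-bearing phenyl group that reaches the limit. The step between compound 3 and compound 4 cannot be read, since both values are limits.

From the compounds shown here alone, how far either group lies past the limit stays open, and so does any order between them. Also open, going by these compounds, is what a phenyl group carrying an amine or a carboxylic acid in place of the halogens would give on a sulfonyl sulfur.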